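A few compounds are considered here, and "the series" means these few. Any claim that something is new, unique, unknown or untested is made for them only; others in the source may bear on it.

Measured so far in a functional assay on NCI/ADR-RES cells (Homo sapiens) for inhibition, read by luminescence, with a stated time of 72 h; a higher number here means a weaker inhibitor, a lower number a stronger inhibitor:
- compound 1 `C[C@H](O)C(=O)N1CCC(CCn2c(Sc3cc4c(cc3Br)CCO4)nc3c(N)ncnc32)CC1`: 11000 nM
- compound 2 `Nc1ncnc2c1nc(Sc1cc3ccoc3cc1Br)n2CCC1CCN(C=O)CC1`: 7900 nM
- compound 3 `Nc1ncnc2c1nc(Sc1cc3c(cc1Br)OCCO3)n2CCC1CCN(C=O)CC1`: 2100 nM

Compound 3 has the lowest number of the three at 2100 nM, and the gaps to both other compounds lie beyond the scatter.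

The next compound to be read is compound 4 `C[C@H](O)C(=O)N1CCC(CCn2c(Sc3cc4c(cc3Br)OCCO4)nc3c(N)ncnc32)CC1`. It differs from compound 3 in one place: 1-hydroxyethyl in place of hydrogen on a carbonyl carbon.

Within the data shown here, no pair of measured compounds isolates this change, so there is no direct precedent for it. Compound 1 carries the same 1-hydroxyethyl group and gives 11000 nM, a higher number than that of compound 3, but the two also differ elsewhere in the structure. Compound 3 shares its formyl end with compound 2, which gives 7900 nM, and this shows that the number also moves without any change at that end. Compound 1 is therefore weak evidence, and it points only to a slight upward lean in this assay.

The expected change is small and probably within the scatter, a 1.4-fold higher number from compound 3 to compound 4 (0.15 log units; within the scatter).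

For compound 4 the estimated value is 3000 nM, with an expected range of 900 nM to 9000 nM.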

Compound 4, half-maximal inhibitory concentration: 6500 nM
Compound 4: middle estimate off by 2.2-fold (0.34 log units), on the low side; the range from low to high includes it.
By their numbers in this assay, from the lowest: compound 3; then compounds 4, 2 and 1 (each within the scatter of the next).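

Taken on its own in this assay, the change at this carbonyl carbon, 1-hydroxyethyl in place of hydrogen, gives a 3.1-fold higher number from compound 3 to compound 4 (0.49 log units; beyond the scatter), the first matched read-out for this position, and it shows that the end of the chain is not neutral when the group on the sulfur is held fixed. With the (1-hydroxyethyl)carbonyl end held fixed instead, the group of 11 heavy atoms in place of the group of 10 heavy atoms on the sulfur gives a 1.7-fold lower number from compound 1 to compound 4 (0.23 log units; within the scatter), so this pair does not separate those two sulfur groups, and with this end in place the pair gives no sign of a sulfur-group effect as large as the step at the carbonyl carbon. No measurement at hand accounts for the step at the carbonyl carbon.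

The compounds shown leave open whether the step follows from the added carbons, the hydroxyl or the defined stereocentre, which a plain acetyl, a 2-hydroxyacetyl or the opposite enantiomer of the 1-hydroxyethyl group would begin to separate. Also open, on these data alone, is how an amine or a carboxylic acid on this carbonyl carbon would read, and whether the step recurs with the other groups on the sulfur.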